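This account rests on a few compounds, and the source may have more. Where it says the series, first, only, none or still open, it means among the compounds named here.

Working notes on the series. Compound 1 `COc1ccc(/C=C/C(=O)NC(=O)c2ccccc2)cc1O` and compound 2 `COc1ccc(/C=C/C(=O)NC(=O)c2ccccc2)cc1` share one core. In a functional assay, with a stated time of 30 min, tested at 1 mM (on this read-out higher numbers stand for more inhibition at the one concentration tested (going by the name of the read-out) and lower numbers for less inhibition), compound 1 gives 7.02%, and compound 2 gives 5.61%. Among the compounds with values here, the single step measured so far is a number 1.4 percentage points lower from compound 1 to compound 2 (within the scatter). Compound 2 therefore stands at the lower of the two numbers shown, with compound 1 nearest, but that gap is within the scatter, so no order between the two is established; both sit near the bottom of the read-out.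

Compound 3 `COc1ccc(/C=C/C(=O)NC(=O)c2ccccc2)cc1OC` is next to be measured. It differs from compound 2 by methoxy in place of hydrogen on an aromatic carbon. Within the data shown here, only the step from compound 1 to compound 2 bears on this, and it stayed within the scatter, so a change to the group on that aromatic carbon has so far not moved the read-out. Compound 3 is expected to show a step of a number 0.4 percentage points higher from compound 2 to compound 3 (within the scatter), nothing beyond the scatter. Compound 3 is estimated at 6%, within a range from 0% to 14%.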

Compound 3, a percentage reported as inhibition, at one concentration (the size of the read-out at that concentration, not a potency): 4.82%
For compound 3 the middle estimate is 1.2 percentage points above the measured one; measured number inside the range.
By their numbers in this assay, from the lowest: compounds 3, 2 and 1 (each within the scatter of the next).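

In this assay, methoxy in place of hydrogen on the aromatic carbon ortho to a methoxy group gives a number 0.8 percentage points lower from compound 2 to compound 3 (within the scatter) and so adds a second group at this position that leaves the read-out unmoved. Methyl in place of hydrogen on the oxygen of compound 1 gives a number 2.2 percentage points lower from compound 1 to compound 3 (within the scatter) and shows that the same holds when the hydroxy is capped, so hydrogen, hydroxy and methoxy at this position stand in no established order. Nothing available accounts for this flat result.

Going by these compounds, whether any group on this aromatic carbon can lift the read-out beyond the scatter stays open, as an amine, a carboxylic acid or a longer alkoxy chain would show. Also open, on these data alone, is whether changes elsewhere on the shared core would move the read-out at all.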